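The source may hold more compounds than are shown below. What is called first, only, known or untested is meant among the compounds shown, and "the series" means these compounds.

Compound 1 `NCCCNc1c(C(=O)NCc2ccc(F)cc2)nc(Br)c2cccnc12`: > 20000 nM
Compound 2 `CNc1c(C(=O)NCc2ccc(F)cc2)nc(Br)c2cccnc12`: > 20000 nM
Compound 3 `CNCCCNc1c(C(=O)NCc2ccc(F)cc2)nc(Br)c2cccnc12`: 9000 nM

All three were tested in a functional assay on HCT-116 cells (Homo sapiens) for cytotoxicity, read by MTT assay, with a stated time of 72 h; on this read-out lower numbers stand for stronger inhibition and higher numbers for weaker inhibition. Compound 1 gives > 20000 nM, which is a limit of the assay and not a number. Compound 2 gives > 20000 nM, which is also a limit. For the measured compounds named here, compound 3, at 9000 nM, holds the only actual number in the set. The comparison of the other two remains a step that the two limits leave unreadable from compound 1 to compound 2.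

The next compound is compound 4 `COC(=O)CNc1c(C(=O)NCc2ccc(F)cc2)nc(Br)c2cccnc12`, not yet measured in this assay. Its difference from compound 3 is methoxycarbonyl in place of 2-(methylamino)ethyl on a saturated chain carbon bound to a nitrogen on an aromatic ring. In short, it carries methoxycarbonyl in place of 2-(methylamino)ethyl on a saturated chain carbon bound to a nitrogen on an aromatic ring.

Going by the values given here, no measured step brings in methoxycarbonyl, so the guidance comes from the group that leaves. Compound 2 lacks that group, and the measured change is an at least 2.2-fold lower number from compound 2 to compound 3 (0.34 log units; beyond the scatter). Removing only the methyl gives a similar picture, seen in an at least 2.2-fold lower number from compound 1 to compound 3 (0.34 log units; beyond the scatter). Compound 4 is therefore expected to lose this modest gain and move towards (the limit of > 20000 nM in this assay, at which 2 of the 3 values shown sit).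

The estimated change is a 2.2-fold higher number from compound 3 to compound 4 (0.35 log units; beyond the scatter), towards weaker inhibition, and the result may well be reported only as a limit. For compound 4 the expected value is 20000 nM, with an estimated range of 7000 nM to 50000 nM.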

Compound 4, half-maximal inhibitory concentration: > 10000 nM
Compound 4 ended at the assay's limit; the forecaster's own chance of this, stated with the estimate: 65%; the middle value lies beyond the limit too.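

Compound 4 carries methoxycarbonyl on a saturated chain carbon bound to a nitrogen on an aromatic ring, and its result in this assay is a limit and not a number: the limit of > 10000 nM in this assay, at which 1 of the 4 values shown sits.

The change from 2-(methylamino)ethyl to methoxycarbonyl at this place reads as an at least 1.1-fold higher number from compound 3 to compound 4 (0.04 log units; that floor lies within the scatter), so this step alone establishes no real loss, and the ester-bearing chain is neither shown to match the 3-(methylamino)propyl chain nor shown to fall short of it. For the compounds shown here, the steps from compound 1 and from compound 2 to compound 4 cannot be read, since both ends of each are limits, and compound 3 remains the only compound in the set with an actual number.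

The compounds shown leave open how far beyond its limit compound 4 really lies, and so whether methoxycarbonyl at this place costs anything against the methylamino chain. They also leave open whether a carboxylic acid in place of the methyl ester, or a dimethylamino group at the end of the longer chain, would give a number that can be compared with that of compound 3.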